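From a hydroxyethyl amide to a cyclohexyl amide

The source may hold more compounds than are shown below. What is called first, only, known or untested is meant among the compounds shown, and "the series" means these compounds.

Of the compounds shown here, three sharing one core have been measured in an assay on CHO cells for displacement of a labelled ligand from adenosine receptor A1 (Homo sapiens), read by scintillation counting, with a stated time of 60 min, tested at 10 uM; a lower number here means less inhibition, a higher number more inhibition at the concentration tested (going by the name of the read-out). Compound 1 `N=c1oc2ccc(Br)cc2cc1C(=O)NCC(O)CO` gives 11%, compound 2 `N=c1oc2ccc(Br)cc2cc1C(=O)NCCO` gives 26%, and compound 3 `COc1cccc2cc(C(=O)NCCO)c(=N)oc12` gives 47%. Compound 2 thus stands second highest of the three, its number lying beyond the scatter from both neighbours: compound 1 sits lower and compound 3 higher. Compound 3 differs from compound 2 in more than one place, so only its value can be set beside that of compound 2.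

The unmeasured compound 4 `N=c1oc2ccc(Br)cc2cc1C(=O)NC1CCCCC1` differs from compound 2 in a single place: cyclohexyl in place of 2-hydroxyethyl on an amide-type nitrogen. Among the compounds with values here, one measured step bears on this change, though only in part. The step of a number 15 percentage points higher from compound 1 to compound 2 (beyond the scatter) shows that trimming a hydroxyl-bearing branch from the amide substituent raised inhibition modestly. Compound 4 goes further and removes the whole 2-hydroxyethyl group in favour of cyclohexyl, with no hydrogen-bond donor or acceptor entering. Within the data shown here, on that single precedent a modest rise is expected, a number 12 percentage points higher from compound 2 to compound 4 (beyond the scatter), with wide uncertainty since no measured pair exchanges a chain for a ring. Compound 4 is therefore estimated at 38% in this assay, within a range of 15% to 60%.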

Compound 4, a percentage reported as inhibition, at one concentration (the size of the read-out at that concentration, not a potency): 5%
The estimate for compound 4 lay 33 percentage points above the measured number, outside the stated range (below it).
By their numbers in this assay, from the lowest: compounds 4 and 1 (each within the scatter of the next); then compound 2; then compound 3.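

In this assay, the substituent on the amide-type nitrogen does not follow a simple rule in which losing hydroxyl-bearing atoms raises the number: the rise seen in a number 15 percentage points higher from compound 1 to compound 2 (beyond the scatter) is not continued, and instead there is a number 21 percentage points lower from compound 2 to compound 4 (beyond the scatter) once cyclohexyl replaces 2-hydroxyethyl. The comparison with the dihydroxylated compound shows a number 6 percentage points lower from compound 1 to compound 4 (within the scatter) as cyclohexyl replaces 2,3-dihydroxypropyl, so these two very different groups cannot be told apart here, while among the three compounds sharing the core of compound 1, only compound 2, with its 2-hydroxyethyl group, stands beyond the scatter from both others. No measurement available here accounts for this outcome.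

The compounds shown leave open whether the lower number of compound 4 goes with the ring, with the size of the group, or with the absence of the hydroxyl, since the change alters all three at once; a hydroxycyclohexyl group or an open hexyl chain on the same nitrogen would begin to separate them. Going by these compounds, it also remains open whether cyclohexyl on the amide of compound 3, with its methoxy-bearing core, would behave in the same way.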